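Fluoro for hydrogen and tolerance on Vero cells

This account rests on a few compounds, and the source may have more. Where it says the series, first, only, none or still open, it means among the compounds named here.

Compound 2 `CCOC(=O)c1c(-c2ccc(OC)cc2)oc2ccc(OCCCCCCN3C(=O)/C(=N\OC)c4ccccc43)cc12` and compound 1 `CCOC(=O)c1c(-c2ccc(OC)cc2)oc2ccc(OCCCCCCN3C(=O)/C(=N\OC)c4cc(F)ccc43)cc12` share one core. In an ADME assay on Vero cells (Chlorocebus sabaeus) for cytotoxicity, read by MTT assay, with a stated time of 72 h (a lower number here means that less compound is tolerated, a higher number that more compound is tolerated), compound 2 gives 32 ug/mL and compound 1 gives 16 ug/mL. They differ by fluoro in place of hydrogen on an aromatic carbon, and the step is a 2.0-fold lower number from compound 2 to compound 1 (0.30 log units; within the scatter).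

Compound 3 `CCOC(=O)c1c(-c2ccc(OC)cc2)oc2ccc(OCCCCCCN3C(=O)C(=O)c4ccccc43)cc12` carries a different core; the difference between the two cores is not broken down here. In this assay compound 3 gives 256 ug/mL, the highest of the three numbers, beyond the scatter from compound 2 and from compound 1.

Compound 4 `CCOC(=O)c1c(-c2ccc(OC)cc2)oc2ccc(OCCCCCCN3C(=O)C(=O)c4cc(F)ccc43)cc12` differs from compound 3 by fluoro in place of hydrogen on an aromatic carbon, the same change as between compound 2 and compound 1, at a place described in the same words. An expected step of a 1.7-fold lower number from compound 3 to compound 4 (0.23 log units; within the scatter) is set beside a 2.0-fold lower number from compound 2 to compound 1 (0.30 log units; within the scatter), since that earlier step lay within the scatter. The expected value for compound 4 in this assay is 150 ug/mL, likely between 60 ug/mL and 400 ug/mL.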

Compound 4, half-maximal cytotoxic concentration: 1020 ug/mL
For compound 4 the middle estimate is 6.8-fold (0.83 log units) below the measured one; the whole stated range lies below it.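

In this assay, fluoro in place of hydrogen on an aromatic carbon gives a 4.0-fold higher number from compound 3 to compound 4 (0.60 log units; beyond the scatter). The change does not carry over as one fixed step between these two cores: the same change on two cores in this assay, a 2.0-fold lower number (0.30 log units; within the scatter) from compound 2 to compound 1 and a 4.0-fold higher number (0.60 log units; beyond the scatter) from compound 3 to compound 4, 8.0-fold (0.90 log units) apart, beyond the scatter of two such steps. This shows that a step read on one core cannot simply be transferred to the other in this series, but it does not show which difference between the cores goes with the gap, and it rests on one pair per core.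

The compounds shown leave open whether chloro or a nitrile in the same place would also give steps that differ between the two cores. They also leave open whether the gap persists with a longer chain.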